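Swapping a Bromophenyl for a Methyl Group

The compounds below may be only part of what the source reports. "The series", "measured", "known", "first", "only" and "open" are said of these compounds alone.

Compound 2 `OC1CCN(Cc2ccc(Br)cc2)CC1N1CCN(c2ccccc2)CC1` carries a 4-bromophenyl on a saturated chain carbon bound to an amine nitrogen in a ring. In an assay on PC-12 cells for displacement of a labelled ligand from vesicular acetylcholine transporter (Homo sapiens) (on this read-out higher numbers stand for weaker inhibition and lower numbers for stronger inhibition), compound 2 gives only a limit, > 100 nM, which is not a measured number. Compound 1 `OC1CCN(Cc2cccc(Br)c2)CC1N1CCN(c2ccccc2)CC1` differs from it solely in the position of the bromine on the aromatic ring, and in this assay compound 1 gives 46 nM. Within the data shown here, the one measured step, an at least 2.1-fold higher number from compound 1 to compound 2 (0.33 log units; beyond the scatter), therefore runs toward weaker inhibition, and it ends at the limit described by the limit of > 100 nM in this assay, at which 1 of the 2 values shown sits.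

Compound 3 `CCN1CCC(O)C(N2CCN(c3ccccc3)CC2)C1` is the compound not yet measured. Relative to compound 2 the change is methyl in place of 4-bromophenyl on a saturated chain carbon bound to an amine nitrogen in a ring, so the whole aromatic ring with its bromine is cut away and only a small methyl remains. Among the measured compounds shown here, no measured pair here removes an aromatic ring, so the single step to hand bears on this only loosely; it shows that compound 2 already sits at the limit, and the expectation is a further move in the same direction, toward weaker inhibition, a step that the limit leaves unreadable from compound 2 to compound 3. For compound 3 the estimated value in this assay is 1500 nM, within 150 nM to 15000 nM.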

Compound 3, half-maximal inhibitory concentration: > 1000 nM
Compound 3 gave a limit, no number; the forecaster's own chance of this, stated with the estimate: 75%; the middle value is on the limit's open side.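

Shortening the group on this carbon has a much larger effect than moving the bromine: an at least 21-fold higher number from compound 1 to compound 3 (1.33 log units; beyond the scatter), a large step toward weaker inhibition when methyl takes the place of 3-bromophenyl on a saturated chain carbon bound to an amine nitrogen in a ring. The earlier pair showed only that the bromine's location on the aromatic ring matters, whereas this step shows that inhibition in this assay also falls sharply once the whole aromatic ring is gone. Compound 2 and compound 3 both end in limits rather than numbers, so the step between them cannot be read: the limit of > 1000 nM in this assay, at which 1 of the 3 values shown sits.

The compounds shown cannot separate the contribution of the bromine from that of the aromatic ring, as every aromatic group at this place still carries a bromine; a plain phenyl would address that point. They also leave open whether a chain alone, such as butyl, could recover any inhibition, or whether a chloro or methoxy group on the ring would behave as the bromine does.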